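This account rests on a few compounds, and the source may have more. Where it says the series, first, only, none or still open, it means among the compounds named here.

Series notes, solubility. Compound 1 `CCCNC(=O)Nc1n[nH]c2c1CN(C(=O)C1CCN(C)CC1)C2(C)C` carries a propylcarbamoyl group on the shared core. In a physicochemical assay for solubility, at pH 7 (a higher number here means a more soluble compound, a lower number a less soluble compound), compound 1 returns a limit of the assay, > 225000 nM, not a number. Compound 2 `CC(C)CC(=O)Nc1n[nH]c2c1CN(C(=O)C1CCN(C3CC3)CC1)C2(C)C` belongs to the same series. In this assay compound 2 likewise returns a limit, > 225000 nM. Within the data shown here, the only evidence so far is the limit of > 225000 nM in this assay, at which 2 of the 2 values shown sit, so neither compound is distinguished from the other, and compound 1 stands at the upper edge of what this assay has resolved. Among the measured compounds shown here, no step between measured compounds is available.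

Compound 3 `CN1CCC(C(=O)N2Cc3c(NC(=O)c4ccc(F)c(F)c4)n[nH]c3C2(C)C)CC1` is the next compound to be measured in this assay. It differs from compound 1 in one place: 3,4-difluorophenyl in place of propylamino on a carbonyl carbon. The change takes out the single hydrogen-bond donor counted in the propylamino group and brings in one six-membered aromatic ring of carbon only, with two fluorines. From the compounds shown here alone, with compound 1 at a limit, the true starting point is unknown, and a step from a limit cannot be measured in full. The expectation for compound 3 is a step downward, an at least 3.7-fold lower number from compound 1 to compound 3 (0.57 log units; beyond the scatter), beyond the scatter. Compound 3 is estimated at 60000 nM, in the range 15000 nM to 225000 nM.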

Compound 3, solubility: > 225000 nM
Compound 3 gave a limit, no number; the forecaster's own chance of this, stated with the estimate: 30%; middle value at least 3.7-fold (0.57 log units) from the limit.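

In this assay compound 3 returns a limit, > 225000 nM, not a number. Among these compounds, no step from compound 1 to compound 3 can be read, as the two compounds share the same limit: the limit of > 225000 nM in this assay, at which 3 of the 3 values shown sit. The compounds shown leave open how far each true value lies past that limit, and whether 3,4-difluorophenyl in place of propylamino shifts the read-out at all.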